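Swapping a Chlorophenyl for a Dihydroxyphenyl

A few compounds are considered here, and "the series" means these few. Any claim that something is new, unique, unknown or untested is made for them only; others in the source may bear on it.

Of the compounds shown here, three sharing one core have been tested in a functional assay on MCF7 cells (Homo sapiens) for cytotoxicity, read by MTT assay, with a stated time of 72 h; a higher number here means a weaker inhibitor, a lower number a stronger inhibitor. Compound 1, `COc1cccc(/C=C2\CCC/C(=C\c3cccc(Cl)c3)C2=O)c1OC`, gives 12000 nM in this assay. Compound 2, `COc1ccc(/C=C2\CCC/C(=C\c3cccc(OC)c3OC)C2=O)c(OC)c1`, reaches only the limit of the measurement, reported as > 20000 nM in this assay; that is a boundary of the method and not a number. Compound 3, `COc1ccc(/C=C2\CCC/C(=C\c3ccccc3Cl)C2=O)cc1OC`, gives 10400 nM in this assay. Among the two numbers that were actually read, compound 3 carries the lower one, and compound 1 sits next to it within the scatter of the method, so the two cannot be told apart. One of the three values is a limit (the limit of > 20000 nM in this assay, at which 1 of the 3 values shown sits).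

Compound 4, `COc1ccc(/C=C2\CCC/C(=C\c3ccc(O)c(O)c3)C2=O)cc1OC`, differs from compound 3 in one place: 3,4-dihydroxyphenyl in place of 2-chlorophenyl on a double-bonded chain carbon bound to a double-bonded ring carbon.

Among the measured compounds shown here, no pair of measured compounds differing in exactly one place is available, so no measured step guides this change. The expectation therefore rests only on the range that compounds 1 and 3 span. For compound 4 the step from compound 3 is estimated as a 1.3-fold lower number from compound 3 to compound 4 (0.11 log units; within the scatter), a shift of modest size, with no firm direction claimed. The estimate for compound 4 in this assay is 8000 nM, expected to fall between 2500 nM and 25000 nM.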

Compound 4, half-maximal inhibitory concentration: 14400 nM
Compound 4: middle estimate off by 1.8-fold (0.26 log units), on the low side; low and high end bracket the measured number.
By their numbers in this assay, from the lowest: compounds 3, 1 and 4 (each within the scatter of the next). At a limit, above all of these: compound 2.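

In this assay, among the compounds shown here, this is the first comparison of two compounds that differ in one place only, and the step is a 1.4-fold higher number from compound 3 to compound 4 (0.14 log units; within the scatter) for this change. On a double-bonded chain carbon bound to a double-bonded ring carbon, then, 2-chlorophenyl and 3,4-dihydroxyphenyl cannot be told apart in this assay, even though the group that leaves has 0 hydrogen-bond donors and 0 hydrogen-bond acceptors and the group that enters has 2 of each. The information available offers no explanation for this lack of a clear difference.

Still open, from the compounds shown here alone, is whether any group at this place can move the number beyond the scatter, for instance a phenyl ring carrying an amine or a carboxylic acid. Also open, going by these compounds, is whether the same swap would give the same small step if the other side of the shared core carried something different from the aromatic group that compound 3 and compound 4 have in common.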